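The source may report more compounds than this note shows. Statements on the series, on what has been measured and on what is new or still open speak of the compounds shown alone.

Compound 1, `COc1cc(-c2ccnc3cc(-c4ccc5cc[nH]c5c4)nn23)cc(OC)c1OC`, in a functional assay on B16-F0 cells (Mus musculus) for inhibition, read by CCK-8 assay, with a stated time of 48 h (on this read-out higher numbers stand for weaker inhibition and lower numbers for stronger inhibition), gives 55 nM. Compound 2, `COc1cc(-c2ccnc3cc(-c4cccc(C)c4)nn23)cc(OC)c1OC`, in this assay gives 2220 nM.

Within the data shown here, compound 2 has the highest number of the two, and its nearest neighbour is compound 1: the single step of a 40-fold higher number from compound 1 to compound 2 (1.61 log units; beyond the scatter) shows how far apart they lie. Compound 3, `COc1cc(-c2ccnc3cc(-c4ccc(C(C)(C)C)cc4)nn23)cc(OC)c1OC`, differs from compound 2 in one place: 4-(tert-butyl)phenyl in place of 3-methylphenyl on an aromatic carbon. Among the measured compounds shown here, no measured step resembles this exchange of one carbon-only six-membered ring for another of the same kind. For the measured compounds named here, the only step known, a 40-fold higher number from compound 1 to compound 2 (1.61 log units; beyond the scatter), replaced a fused two-ring group and so says little about a larger group on a single ring. The expectation for compound 3 in this assay is therefore a step of about a 1.1-fold higher number from compound 2 to compound 3 (0.05 log units; within the scatter), that is nothing clearly beyond the scatter, with wide uncertainty. Compound 3 is estimated at 2500 nM, within a range from 700 nM to 9000 nM.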

Compound 3, half-maximal inhibitory concentration: > 10000 nM
Compound 3: a limit, no number; the forecaster's own chance of this, stated with the estimate: 10%; at least 4.0-fold (0.60 log units) between middle value and limit.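

In this assay compound 3 gives a limit of the assay and not a number: the limit of > 10000 nM in this assay, at which 1 of the 3 values shown sits.

Even so, this position on the five-membered ring does not respond only to the loss of a fused two-ring group: keeping one six-membered aromatic ring of carbon only and changing 3-methylphenyl to 4-(tert-butyl)phenyl still gives an at least 4.5-fold higher number from compound 2 to compound 3 (0.65 log units; beyond the scatter). Against the 1H-indol-6-yl group the gap is wider, with an at least 180-fold higher number from compound 1 to compound 3 (2.25 log units; beyond the scatter), and of these three compounds, compound 1 keeps the lowest number.

The names 3-methylphenyl and 4-(tert-butyl)phenyl differ both in the group carried and in where it sits on the ring, so these compounds do not separate the two changes; 4-methylphenyl would be the missing link. Also open, as far as these compounds go, is how naphthyl, a two-ring group of carbon only, or a phenyl ring carrying an amine would behave here.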